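Swapping Chloro for Methoxy on an Aromatic Carbon

This account rests on a few compounds, and the source may have more. Where it says the series, first, only, none or still open, it means among the compounds named here.

Among the compounds with values here, compound 1 `CCc1nc(-c2ccccc2F)c(C(=O)N2CCN(c3cccc(Cl)c3)CC2)o1` gives 139 nM in a functional assay on HL-60 cells (Homo sapiens) for inhibition, read by MTT assay, with a stated time of 72 h (a lower number here means a stronger inhibitor, a higher number a weaker inhibitor), the only number in this set. Compound 2 `O=C(c1oc(C(F)(F)F)nc1-c1ccccc1F)N1CCN(c2cccc(Cl)c2)CC1` is recorded in this assay as "not active" (no number reported), with no number reported. Compound 3 `CCc1nc(-c2ccccc2F)c(C(=O)N2CCN(c3cccc(OC)c3)CC2)o1` differs from compound 1 by methoxy in place of chloro on an aromatic carbon. Within the data shown here, no measured pair shows this change, so the expected step of a 1.8-fold higher number from compound 1 to compound 3 (0.25 log units; within the scatter) is small, a mild weakening at most and possibly nothing beyond the usual scatter. Compound 3 is therefore estimated at 250 nM in this assay, with a range from 80 nM to 900 nM.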

Compound 3, half-maximal inhibitory concentration: 607 nM
Estimate against measurement, compound 3: 2.4-fold (0.39 log units) below; the measured number falls inside the stated range.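

In this assay the change from chloro to methoxy gives a 4.4-fold higher number from compound 1 to compound 3 (0.64 log units; beyond the scatter), so this position on the aromatic ring responds to which group it carries, and here the 3-chlorophenyl compound holds the lower number. Compound 3 still gives a measurable number, so methoxy weakens inhibition without abolishing it. Nothing available explains this step. The compounds shown leave open how a fluoro, a hydroxyl or an amine would compare with chloro at this position, and whether any such group would improve on compound 1.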